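From chloro to cyano: a half-life estimate for compound 4

The source may hold more compounds than are shown below. What is called first, only, known or untested is meant among the compounds shown, and "the series" means these compounds.

In an ADME assay on microsomes from liver (Homo sapiens) for metabolic stability, read by LC-MS, using NADPH, with a stated time of 10 min, tested at 10 uM (on this read-out lower numbers stand for a shorter-lived compound and higher numbers for a longer-lived compound), compound 1 `CC(C)(C)n1nc(Oc2cc(Cl)ccn2)c2c(N)ncnc21` gives 1 h. Compound 3 `Nc1ncnc2c1c(Oc1cc(Cl)ccn1)nn2C1CC1` gives 1.05 h, and these two numbers cannot be told apart: the data show a 1.1-fold higher number from compound 1 to compound 3 (0.02 log units; within the scatter). Compound 2 `Nc1ncnc2c1c(Oc1cc(Cl)ccn1)nn2C1CCC1` gives 0.333 h, so compound 1 stands in the upper pair of the three numbers.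

Compound 4 `CC(C)(C)n1nc(Oc2cc(C#N)ccn2)c2c(N)ncnc21` keeps the tert-butyl group and the shared core of compound 1 and differs in one place: cyano in place of chloro on an aromatic carbon. This puts cyano in place of chloro on an aromatic carbon, opposite the ring nitrogen.

Within the data shown here, no measured step touches that place. All three steps swap the group on the aromatic nitrogen, and every measured compound carries the chloro, so there is no direct evidence on cyano. The steps show only how far one change has moved the half-life in this small set. The two that involve compound 2 are modest, at a 3.0-fold lower number from compound 1 to compound 2 (0.48 log units; beyond the scatter) and a 3.2-fold higher number from compound 2 to compound 3 (0.50 log units; beyond the scatter). A step of similar size in either direction is therefore possible, but with no direction indicated, none beyond the scatter is expected. The expected step is a 1.1-fold higher number from compound 1 to compound 4 (0.04 log units; within the scatter). For compound 4, the estimated half-life is 1.1 h, with an expected range from 0.45 h to 2.5 h.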

Compound 4, half-life: > 2.41 h
Compound 4 gave a limit, no number (the forecaster's own chance of this, stated with the estimate: 3%); middle value at least 2.1-fold (0.34 log units) away from the limit.
By their numbers in this assay, from the lowest: compound 2; then compounds 1 and 3 (each within the scatter of the next). At a limit, above all of these: compound 4.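

Among these compounds, until this result, every compound carried the chloro, and the only changes were to the group on the aromatic nitrogen, so nothing showed whether the other end of the molecule mattered for half-life. With the tert-butyl group and the shared core held constant, placing cyano in place of chloro on an aromatic carbon, opposite the ring nitrogen, gives an at least 2.4-fold higher number from compound 1 to compound 4 (0.38 log units; beyond the scatter), which shows that this position can change the read-out in this assay and that this swap moves it towards a longer-lived compound. Compound 4 gives > 2.41 h, which is a limit of the assay and not a number, so this change is shown only to reach that limit, and its full size stays unknown.

The cyano is shown here only with the tert-butyl group, so it remains open whether the same swap would lengthen the half-life with cyclobutyl or cyclopropyl on the aromatic nitrogen. On these data alone, it is also open how other groups would behave at this position, such as a methoxy group, a methyl group or a primary amide, and so whether the gain is particular to cyano.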